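A few compounds are considered here, and "the series" means these few. Any claim that something is new, unique, unknown or untested is made for them only; others in the source may bear on it.

Series notes. In an assay on NK92 cells for inhibition of interleukin-15 (Homo sapiens), read by AlphaScreen, with stated times of 30 min and 1 h (a lower number here means a stronger inhibitor, a higher number a weaker inhibitor), the three measured compounds span a wide window. Compound 1 `CCOC(CCn1c(Cc2nn(C)c(=O)c3ccccc23)nnc1SCCCCCCCC(=O)Nc1ccc(Cl)cc1Cl)OCC` gives 30000 nM. Among the compounds with values here, compound 2 `Cn1nc(Cc2nnc(SCCCCCCCC(=O)Nc3ccc(Cl)cc3Cl)n2CCC=O)c2ccccc2c1=O` gives 710 nM; the step of a 42-fold lower number from compound 1 to compound 2 (1.63 log units; beyond the scatter) is the only single-point change so far. Compound 3 `Cn1c(Cc2nn(CCC3OCCO3)c(=O)c3ccccc23)nnc1SCC(=O)Nc1ccc(Cl)cc1Cl` gives 30000 nM, level with compound 1 at the digits printed, and the two together sit at the top of the three numbers, with compound 2 the furthest from them.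

Compound 4 `Cn1c(Cc2nn(CCC(=O)O)c(=O)c3ccccc23)nnc1SCC(=O)Nc1ccc(Cl)cc1Cl` is the next point. Its difference from compound 3 is carboxy in place of 1,3-dioxolan-2-yl on a saturated chain carbon, two bonds along the chain from an aromatic nitrogen. Within the data shown here, no measured pair shows this exact change; the nearest precedent is the step of a 42-fold lower number from compound 1 to compound 2 (1.63 log units; beyond the scatter), where a protected acetal on the same kind of chain position gave way to a carbonyl-bearing group and the number fell sharply. Carboxy is not formyl, and compound 3 carries a shorter sulfur-linked amide chain than compound 1, so the precedent transfers only loosely. Among the measured compounds shown here, a downward step is nevertheless expected, a 3.8-fold lower number from compound 3 to compound 4 (0.57 log units; beyond the scatter), smaller than the one from compound 1 to compound 2. Compound 4 is therefore estimated at 8000 nM, within 2000 nM to 30000 nM.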

Compound 4, half-maximal inhibitory concentration: > 30000 nM
Compound 4 was reported as a limit; the forecaster's own chance of this, stated with the estimate: 30%; middle value at least 3.7-fold (0.57 log units) away from the limit.
By their numbers in this assay, from the lowest: compound 2; then compounds 1 and 3 (each within the scatter of the next).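

In this assay compound 4 gives > 30000 nM, which is a limit of the assay and not a number. The step, a number no lower from compound 3 to compound 4 (the limit leaves the size open), therefore shows only that carboxy in place of 1,3-dioxolan-2-yl brings no lower number, and its size cannot be read because compound 4 sits at that limit: the limit of > 30000 nM in this assay, at which 1 of the 4 values shown sits. A carbonyl-bearing group at this kind of chain position thus does not by itself bring a drop such as a 42-fold lower number from compound 1 to compound 2 (1.63 log units; beyond the scatter), although compounds 3 and 4 differ from compounds 1 and 2 in more than one place, so the two changes are only loosely comparable.

Going by these compounds, whether formyl on the frame of compound 3 would match the drop seen with compound 2 stays open. So does the outcome for an amine, a primary amide or a hydroxyl at the end of this chain.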